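A few compounds are considered here, and "the series" means these few. Any claim that something is new, unique, unknown or untested is made for them only; others in the source may bear on it.

Values so far in this series, from a functional assay on UACC-62 cells (Homo sapiens); a higher number here means a weaker inhibitor of growth, a lower number a stronger inhibitor of growth
- compound 1 `O=S(=O)(/C=C/c1ccc(F)cc1)Cc1ccc(Nc2ncnc3ccccc23)cc1` gives 5000 nM
- compound 2 `O=S(=O)(/C=C/c1ccc(Cl)c(Cl)c1)Cc1ccc(Nc2ncnc3ccccc23)cc1` gives 21000 nM

Going by the values given here, compound 2 holds the higher of the two numbers, which makes it the weaker growth inhibitor of this pair, and compound 1 is its only neighbour. The next compound is compound 3 `O=S(=O)(/C=C/c1ccc(Br)cc1)Cc1ccc(Nc2ncnc3ccccc23)cc1` and the change leading to it is 4-bromophenyl in place of 3,4-dichlorophenyl on a double-bonded chain carbon bound to a double-bonded chain carbon at that same place in the chain.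

Among the compounds with values here, one measured step bears on this change, the modest 4.2-fold higher number from compound 1 to compound 2 (0.62 log units; beyond the scatter) with 3,4-dichlorophenyl replacing 4-fluorophenyl. Within the data shown here, no measured compound carries 4-bromophenyl, and a single step fixes no trend. The 3,4-dichlorophenyl of compound 2 stands with 21000 nM and is gone in compound 3, so a step to a lower number in this assay is expected, no larger than about the size of that measured step. The expected move is a 2.3-fold lower number from compound 2 to compound 3 (0.37 log units; beyond the scatter) and this estimate carries a wide margin. In this assay the estimate for compound 3 is 9000 nM with an expected range of 3000 nM to 25000 nM for this value.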

Compound 3, concentration for 50% growth inhibition: > 100000 nM
Compound 3 gave a limit, no number; the forecaster's own chance of this, stated with the estimate: 5%; at least 11-fold (1.04 log units) between middle value and limit.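

In this assay compound 3 gives a limit and not a number, so its true position is unfixed and only the size of its steps can be bounded: the limit of > 100000 nM in this assay, at which 1 of the 3 values shown sits.

Even so, the 4-bromophenyl group does not land near the earlier two groups at this place on the chain: the change from 3,4-dichlorophenyl gives an at least 4.7-fold higher number from compound 2 to compound 3 (0.67 log units; beyond the scatter), and bromo in place of fluoro on an aromatic carbon gives an at least 20-fold higher number from compound 1 to compound 3 (1.30 log units; beyond the scatter). The first pair hinted only at a moderate range at this position, with a 4.2-fold higher number from compound 1 to compound 2 (0.62 log units; beyond the scatter), whereas the three compounds now show that changing the halogen on the aromatic ring alone can weaken growth inhibition considerably more than that, and compound 1 stands as the strongest of the three.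

Three halogenated phenyl groups cannot separate an effect of the particular halogen from one of the substitution pattern, and a 4-chlorophenyl group would bear directly on that question. On these data alone, whether an unsubstituted phenyl, a 4-methoxyphenyl or a phenyl carrying an amine at this place would stay near compound 1 or fall toward compound 3 remains open.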